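The source may report more compounds than this note shows. Statements on the series, on what has been measured and on what is new or still open speak of the compounds shown alone.

Measured compounds:
compound 1 `Cc1ccc(-n2cc(COc3cccc4cnc(Nc5cccc(Cl)c5)nc34)nn2)c([N+](=O)[O-])c1` – 4000 nM
compound 2 `Clc1cccc(Nc2ncc3cccc(OCc4cn(-c5ccc(Br)cc5)nn4)c3n2)c1` – 9000 nM

Within the data shown here, in a functional assay on MCF7 cells (Homo sapiens) for cytotoxicity, read by cell counting, with a stated time of 48 h (on this read-out higher numbers stand for weaker inhibition and lower numbers for stronger inhibition), compound 1 gives 4000 nM, the lowest of the two numbers; its only neighbour, compound 2, gives 9000 nM. Compound 3 `Clc1cccc(Nc2ncc3cccc(OCc4cn(-c5cc(Cl)cc(Cl)c5)nn4)c3n2)c1` is not yet measured and differs from compound 1 by 3,5-dichlorophenyl in place of 4-methyl-2-nitrophenyl on an aromatic nitrogen. Among the measured compounds shown here, the one measured step that bears on this change, a 2.3-fold higher number from compound 1 to compound 2 (0.35 log units; beyond the scatter), exchanged the same 4-methyl-2-nitrophenyl for 4-bromophenyl on the same aromatic nitrogen. A step of like direction and comparable size is therefore expected for compound 3, a 1.8-fold higher number from compound 1 to compound 3 (0.24 log units; within the scatter), with the usual uncertainty of a single comparison. Compound 3 is estimated at 7000 nM, within 3000 nM to 16000 nM.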

Compound 3, half-maximal inhibitory concentration: 5000 nM
The estimate for compound 3 lay 1.4-fold (0.15 log units) above the measured number; the range from low to high includes it.
By their numbers in this assay, from the lowest: compounds 1, 3 and 2 (each within the scatter of the next, the first and the last beyond it).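

Among these compounds, on the aromatic nitrogen of the five-membered ring, 3,5-dichlorophenyl in place of 4-methyl-2-nitrophenyl gives a 1.3-fold higher number from compound 1 to compound 3 (0.10 log units; within the scatter), so losing the nitro and methyl groups leaves no step that can be read. Set against 4-bromophenyl, the same group gives a 1.8-fold lower number from compound 2 to compound 3 (0.26 log units; within the scatter), so 3,5-dichlorophenyl cannot be separated from either of the other two aryl groups, although those two lie beyond the scatter of each other. No measurement on hand accounts for these numbers.

Open, going by these compounds, is how a benzyl, a cyclohexyl or a phenyl carrying a carboxylic acid would read on this nitrogen. Also open, on these data alone, is whether any group here moves the number far from this narrow span.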